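This account rests on a few compounds, and the source may have more. Where it says the series, first, only, none or still open, it means among the compounds named here.

Compound 3 `CCOC(=O)/C=C1/[C@H](C)O[C@@H](O[Si](C)(C)C(C)(C)C)C[C@@H]1OC` is the starting point of this step. In a functional assay on the whole organism for inhibition, with Artemia salina as the target (a higher number here means a weaker inhibitor of growth, a lower number a stronger inhibitor of growth), compound 3 gives 0.01 ug/mL. Compound 2 `CO[C@H]1C[C@H](O[Si](C)(C)C(C)(C)C)O[C@@H](C)/C1=C/CCl` gives 0.01 ug/mL in this assay, and the step from compound 2 to compound 3, ethoxycarbonyl in place of chloromethyl on a double-bonded chain carbon bound to a double-bonded ring carbon, is no change at the digits printed from compound 2 to compound 3 (within the scatter). These two compounds therefore stand together at the top of the three numbers. Compound 1 `C=CCOC(=O)/C=C1/[C@H](C)O[C@@H](O[Si](C)(C)C(C)(C)C)C[C@@H]1OC` gives 0.002 ug/mL, and the step from compound 1 to compound 3 is a number 2.3 two-fold dilutions higher from compound 1 to compound 3 (beyond the scatter); the step from compound 1 to compound 2 is a number 2.3 two-fold dilutions higher from compound 1 to compound 2 (beyond the scatter).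

Compound 4 `CO[C@H]1C[C@H](O[Si](C)(C)C(C)(C)C)O[C@@H](C)/C1=C/C#N` differs from compound 3 by cyano in place of ethoxycarbonyl on a double-bonded chain carbon bound to a double-bonded ring carbon. Two of the measured steps touch the same double-bonded chain carbon: from compound 2 to compound 3 it was no change at the digits printed from compound 2 to compound 3 (within the scatter), and from compound 1 to compound 2 it was a number 2.3 two-fold dilutions higher from compound 1 to compound 2 (beyond the scatter). Exchanging the group at this position has so far produced at most a modest shift, so a step of modest size or none beyond the scatter is expected in this assay. Compound 4 is therefore estimated at 0.01 ug/mL, with a range from 0.0025 ug/mL to 0.04 ug/mL, which corresponds to an expected step of no change at the digits printed from compound 3 to compound 4 (within the scatter).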

Compound 4, minimum inhibitory concentration: 0.0005 ug/mL
Compound 4: middle estimate off by 4.3 two-fold dilutions, on the high side; the whole stated range lies above it.
By their numbers in this assay, from the lowest: compound 4; then compound 1; then compounds 2 and 3 (each within the scatter of the next).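

In this assay, for the compounds shown here, the double-bonded chain carbon bound to a double-bonded ring carbon proves far more sensitive to its substituent than the earlier compounds suggested. The change from chloromethyl to ethoxycarbonyl had given no change at the digits printed from compound 2 to compound 3 (within the scatter) and so made the groups here look interchangeable, yet cyano in place of ethoxycarbonyl gives a number 4.3 two-fold dilutions lower from compound 3 to compound 4 (beyond the scatter) and cyano in place of chloromethyl gives a number 4.3 two-fold dilutions lower from compound 2 to compound 4 (beyond the scatter), both large steps toward stronger inhibition of growth. Cyano also surpasses allyloxycarbonyl, the best of the earlier groups, with a number 2 two-fold dilutions lower from compound 1 to compound 4 (beyond the scatter), which places compound 4 as the strongest inhibitor of the four and shows that the identity of the group at this position can matter greatly.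

The data shown offer no measured explanation for why cyano stands apart from the other groups. As far as these compounds go, it remains open whether the gain is specific to cyano or would persist with a carboxylic acid, a primary amide or a cyanomethyl group at this position, and whether it would hold on a core without the silyl ether shared by all four compounds.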